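A few compounds are considered here, and "the series" means these few. Any claim that something is new, unique, unknown or untested is made for them only; others in the source may bear on it.

Compound 1 `N#CC1=C(N)N(c2ccc(S(N)(=O)=O)cc2)C2=C(CCCC2)C1c1ccccc1` gives 10% in a functional assay on Ehrlich cells (Mus musculus) for cytotoxicity, read by trypan blue exclusion, with a stated time of 2 h, tested at 25 ug/mL; on this read-out higher numbers stand for a stronger effect at the one concentration tested and lower numbers for a weaker effect. Compound 2 `Cc1ccc(C2C(C#N)=C(N)N(c3ccc(S(N)(=O)=O)cc3)C3=C2CCCC3)cc1` gives 30%, and compound 3 `COc1ccccc1C1C(C#N)=C(N)N(c2ccc(S(N)(=O)=O)cc2)C2=C1CCCC2` gives 40%. Compound 3 stands highest of the three numbers; its gap to compound 2 lies within the scatter, while a number 30 percentage points higher from compound 1 to compound 3 (beyond the scatter) and a number 20 percentage points higher from compound 1 to compound 2 (beyond the scatter) lie beyond it. Compound 4 `N#CC1=C(N)N(c2ccc(S(N)(=O)=O)cc2)C2=C(CCCC2)C1c1ccccc1Cl` differs from compound 3 by chloro in place of methoxy on an aromatic carbon. Within the data shown here, no measured step exchanges methoxy for chloro; the steps that bear on it are a number 30 percentage points higher from compound 1 to compound 3 (beyond the scatter), where methoxy in place of hydrogen raised the number, and a number 10 percentage points higher from compound 2 to compound 3 (within the scatter), which lies within the scatter. For compound 4 a step within the scatter, if any, is therefore expected in this assay, a number 5 percentage points lower from compound 3 to compound 4 (within the scatter). Compound 4 is estimated at 35%, between 15% and 55%.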

Compound 4, a percentage reported as activity, at one concentration (the size of the read-out at that concentration, not a potency): 0%
Compound 4: middle estimate off by 35 percentage points, on the high side, and the stated range ends above it.
By their numbers in this assay, from the lowest: compounds 4 and 1 (each within the scatter of the next); then compounds 2 and 3 (each within the scatter of the next).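

In this assay the outcome at this position, ortho to a large group, turns on which group sits there: a number 40 percentage points lower from compound 3 to compound 4 (beyond the scatter) with chloro in place of methoxy, whereas a number 10 percentage points lower from compound 1 to compound 4 (within the scatter) with chloro in place of hydrogen. Chloro therefore does not stand apart from hydrogen here, and the gain seen with methoxy does not carry over to any group filling this place. Swapping 4-methylphenyl for 2-chlorophenyl also costs activity, with a number 30 percentage points lower from compound 2 to compound 4 (beyond the scatter) on that change. Nothing measured here accounts for these differences. Going by these compounds, whether the gain belongs to methoxy alone stays open: a hydroxy group, an ethoxy group or an amine at this position would test it.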